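Swapping the carbamate on the indoline nitrogen for a pyrimidine

This account rests on a few compounds, and the source may have more. Where it says the series, first, only, none or still open, it means among the compounds named here.

Of the compounds shown here, two have been measured so far. Compound 1 `O=C(OC1CC1)N1CCc2cc(C3(C(=O)Nc4ccc(F)cc4)CCC3)ccc21` gives 41 nM in an assay on blood for inhibition of Indoleamine 2,3-dioxygenase 1 (Homo sapiens) (a lower number here means a stronger inhibitor, a higher number a weaker inhibitor), the lowest of the two numbers. Within the data shown here, compound 2 `O=C(NC1(c2ccc3c(n2)CCN3c2ccnc(C(F)(F)F)n2)CCC1)c1ccc(Cl)cc1` gives 240 nM in this assay, a number beyond the scatter above that of compound 1; the two differ in several places at once, so no single step connects them.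

Compound 3 `Cc1nccc(N2CCc3cc(C4(C(=O)Nc5ccc(F)cc5)CCC4)ccc32)n1` is not yet measured. It differs from compound 1 in one place: 2-methylpyrimidin-4-yl in place of cyclopropyloxycarbonyl on a nitrogen on an aromatic ring in a ring. Among the measured compounds shown here, no measured pair shows this exact change, so its size can only be guessed. Compound 2 also bears a pyrimidine on its ring nitrogen and sits at 240 nM, a weaker reading, which points toward some loss. Compound 3 is therefore expected to land a step of a 2.2-fold higher number from compound 1 to compound 3 (0.34 log units; beyond the scatter) from compound 1, at an estimated 90 nM, within a range from 30 nM to 300 nM.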

Compound 3, half-maximal inhibitory concentration: 430 nM
Beside the measured number, compound 3's estimate is 4.8-fold (0.68 log units) below it; measured number above the stated range.
By their numbers in this assay, from the lowest: compound 1; then compounds 2 and 3 (each within the scatter of the next).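

In this assay, among these compounds, replacing the carbamate on this nitrogen gives the first single-place step, a 10-fold higher number from compound 1 to compound 3 (1.02 log units; beyond the scatter), so the group at this position has a large effect on the number. The size of the step stands out. Cyclopropyloxycarbonyl and 2-methylpyrimidin-4-yl have the same count of hydrogen-bond donors and acceptors, neither carries a net charge, and they differ by only one heavy atom. Nothing available here explains why the step is this large.

On these data alone, it remains open whether the loss comes from the methyl group or from the pyrimidine ring itself, a question that a plain pyrimidin-4-yl on this nitrogen could address. As far as these compounds go, whether an acetyl or a methyl carbamate would hold the number near that of compound 1 also remains open.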